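This account rests on a few compounds, and the source may have more. Where it says the series, first, only, none or still open, it means among the compounds named here.

Measured compounds in an ADME assay on NIH3T3 cells (Mus musculus) for cytotoxicity, read by MTT assay, with a stated time of 24 h; on this read-out higher numbers stand for weaker inhibition and lower numbers for stronger inhibition:

Compound 1 `Cc1ccc(-c2cs/c(=N/NC(=O)CSc3ncccn3)n2-c2ccccc2)cc1`: in this assay compound 1 gives > 500 ug/mL, which is a limit of the assay and not a number.
Compound 2 `O=C(CSc1ncccn1)N/N=c1/scc(-c2ccccc2)n1-c1ccccc1`: in this assay compound 2 gives 107 ug/mL.
Compound 3 `O=C(CSc1ncccn1)N/N=c1/scc(-c2ccc(Cl)cc2)n1-c1ccccc1`: in this assay compound 3 gives 397 ug/mL.

Compound 1 stands only at the limit of > 500 ug/mL in this assay, at which 1 of the 3 values shown sits, so its true number is not known. The measured steps all change the substituent on an aromatic carbon of the shared core: an at least 4.6-fold lower number from compound 1 to compound 2 (0.66 log units; beyond the scatter); an at least 1.2-fold lower number from compound 1 to compound 3 (0.10 log units; that floor lies within the scatter); a 3.7-fold higher number from compound 2 to compound 3 (0.57 log units; beyond the scatter). The unmeasured compound 4 `Cc1ccc(-c2cs/c(=N/NC(=O)CSc3nnc(C)s3)n2-c2ccccc2)cc1` differs from compound 1 at another place: 5-methyl-1,3,4-thiadiazol-2-yl in place of pyrimidin-2-yl on a sulfur. Within the data shown here, none of the measured steps touches the group on that sulfur, so no measured step bears directly on this change, and the available steps give no direction for it. The expected outcome is therefore a step of no size beyond the scatter, a number no higher from compound 1 to compound 4 (the limit leaves the size open), with compound 1 itself known only as a limit. Compound 4 is estimated at 500 ug/mL, expected to lie between 250 ug/mL and 1000 ug/mL, with a real chance that this assay again reports only a limit for compound 4.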

Compound 4, half-maximal inhibitory concentration: 373 ug/mL
Compound 4: middle estimate off by 1.3-fold (0.13 log units), on the high side; low and high end bracket the measured number.
By their numbers in this assay, from the lowest: compound 2; then compounds 4 and 3 (each within the scatter of the next). At a limit, above all of these: compound 1.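

In this assay, among these compounds, the group on the sulfur varies here for the first time, and 5-methyl-1,3,4-thiadiazol-2-yl in place of pyrimidin-2-yl yields a measured number, with the step reading an at least 1.3-fold lower number from compound 1 to compound 4 (0.12 log units; that floor lies within the scatter). The floor of that step lies within the scatter, so this swap is not shown to lower the number beyond the scatter, though a larger drop remains possible. The true size of the step cannot be read because compound 1 is known only as a limit: the limit of > 500 ug/mL in this assay, at which 1 of the 4 values shown sits.

Going by these compounds, whether an amine, a carboxylic acid or a longer alkyl chain on this sulfur would give a different number remains open. Also open, on these data alone, is whether 5-methyl-1,3,4-thiadiazol-2-yl gives the same kind of step on the cores of compound 2 and compound 3, which carry hydrogen and chloro in place of methyl.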